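This account rests on a few compounds, and the source may have more. Where it says the series, first, only, none or still open, it means among the compounds named here.

Measured so far in a functional assay on KYSE-410 cells (Homo sapiens) for antiproliferative activity, read by MTT assay, with a stated time of 72 h (a higher number here means a weaker inhibitor, a lower number a stronger inhibitor), each value a limit of the assay and not a number:

- Compound 1 `COc1ccc(OC)c(NC(=O)c2cc(=O)[nH]c3cc(Br)ccc23)c1`: > 20000 nM
- Compound 2 `O=C(Nc1cccc(Cl)c1)c1cc(=O)[nH]c2cc(Br)ccc12`: > 20000 nM
- Compound 3 `CC(=O)c1ccc(-c2ccc3c(C(=O)Nc4cccc(F)c4)cc(=O)[nH]c3c2)cc1`: > 20000 nM

Compound 3 gives > 20000 nM in this assay, and this is a limit, not a measured number. Compound 3 therefore has no exact place on the scale, and it shares its position with compound 1 and compound 2 at the limit of > 20000 nM in this assay, at which 3 of the 3 values shown sit.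

Compound 4 `Cc1ccc(-c2ccc3c(C(=O)Nc4cccc(F)c4)cc(=O)[nH]c3c2)cc1` differs from compound 3 in one place: methyl in place of acetyl on an aromatic carbon. In short, the 4-acetylphenyl of compound 3 becomes the 4-methylphenyl of compound 4.

Among the measured compounds shown here, no pair of measured compounds shows what a change of this kind does in this assay, and no exact value is available as a starting point. The expectation therefore rests on (the limit of > 20000 nM in this assay, at which 3 of the 3 values shown sit), and compound 4 may well report only a limit too. The expected step is a number no higher from compound 3 to compound 4 (the limit leaves the size open), which means no change beyond the usual scatter is expected, although a measurable value on the stronger side remains possible. For compound 4 the estimated value is 20000 nM, with an expected range from 6000 nM to 40000 nM.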

Compound 4, half-maximal inhibitory concentration: > 20000 nM
Compound 4 ended at the assay's limit (the forecaster's own chance of this, stated with the estimate: 70%); the middle value lies on the limit itself.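

In this assay compound 4 gives > 20000 nM, which is a limit and not a number. Compound 3 also stands at a limit, so no step can be read between the two. The compounds shown leave open how strong any of them truly is, and which change, if any, would give a measurable value: the limit of > 20000 nM in this assay, at which 4 of the 4 values shown sit.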